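Two thiourea analogues and a second chloro substituent

The compounds below may be only part of what the source reports. "The series", "measured", "known", "first", "only" and "open" are said of these compounds alone.

The set holds two measured compounds of quite different build. Compound 1, with the structure `N#C/C(=C\N1CCN(C(=O)c2ccco2)C1=S)C(=O)c1ccccc1`, gives in a functional assay on UACC-62 cells (Homo sapiens) for inhibition, read by sulforhodamine B assay, with a stated time of 48 h (a lower number here means a stronger inhibitor of growth, a higher number a weaker inhibitor of growth), a value of 12900 nM. Compound 2, with the structure `O=CN1CCN(c2ccc(Cl)cc2)C1=S`, gives in this assay a value of 15900 nM. Compound 2 stands alongside compound 1: the two numbers lie within the usual scatter of each other, so no order between them can be read from the data.

Compound 3, with the structure `O=CN1CCN(c2ccc(Cl)c(Cl)c2)C1=S`, has not yet been measured. It differs from compound 2 in one place: chloro in place of hydrogen on an aromatic carbon. Among the measured compounds shown here, no measured pair in the set shows the effect of such a change, so the data give no direction for it. For the measured compounds named here, the account therefore expects no step in this assay beyond the scatter, with the estimated step from compound 2 to compound 3 being a 1.3-fold lower number from compound 2 to compound 3 (0.12 log units; within the scatter). For compound 3 the estimated value in this assay is 12000 nM, expected to fall between 5000 nM and 30000 nM.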

Compound 3, concentration for 50% growth inhibition: 16000 nM
The estimate for compound 3 lay 1.3-fold (0.12 log units) below the measured number, and the stated range covers the measured number.
By their numbers in this assay, from the lowest: compounds 1, 2 and 3 (each within the scatter of the next).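

Among the compounds shown here, the step of a 1.0-fold higher number from compound 2 to compound 3 (0.00 log units; within the scatter) is the first measured pair in the set that differs in one place, and it gives a reading in this assay for a change the earlier compounds could not speak to. At this position, on an aromatic carbon ortho to a chloro group and meta to a group of 8 heavy atoms, chloro in place of hydrogen leaves compound 3 within the scatter of compound 2, so the position accepts this added chlorine atom with no readable difference in growth inhibition. Nothing available bears on the reason for this result.

The compounds shown leave open whether a different group at this same position, such as an amine, a carboxylic acid or a longer chain, would in this assay also stay within the scatter of compound 2. They also leave open whether chloro in place of hydrogen on another aromatic carbon of this ring, or the removal of the chloro group already present in compound 2, would give a step beyond the scatter.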